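This account rests on a few compounds, and the source may have more. Where it says the series, first, only, none or still open, it means among the compounds named here.

Measured compounds:
compound 1, `O=C(Nc1cccc(CNc2ncnc3ccccc23)c1)Nc1ccccc1F`, gives 26100 nM;
compound 2, `O=C(Nc1ccc(F)cc1)Nc1cccc(CNc2ncnc3ccccc23)c1`, gives 21000 nM;
compound 3, `COc1cc2ncnc(NCc3cccc(NC(=O)Nc4ccccc4F)c3)c2cc1OC`, gives 23800 nM.

All three were tested in a functional assay on A549 cells (Homo sapiens) for antiproliferative activity, read by MTT assay (a lower number here means a stronger inhibitor, a higher number a weaker inhibitor), and their numbers lie close together. Compound 1 and compound 2 share a core and differ only by 4-fluorophenyl in place of 2-fluorophenyl on an amide-type nitrogen; that change produced a 1.2-fold lower number from compound 1 to compound 2 (0.09 log units; within the scatter). Compound 3 carries a different core, and the difference between the cores of compound 1 and compound 3 is not broken down here; their two values lie within the scatter of each other. Compound 4, `COc1cc2ncnc(NCc3cccc(NC(=O)Nc4ccc(F)cc4)c3)c2cc1OC`, has not yet been measured. It differs from compound 3 by 4-fluorophenyl in place of 2-fluorophenyl on an amide-type nitrogen, the same change at the same place as that seen from compound 1 to compound 2. Compound 4 is therefore expected to show a 1.2-fold lower number from compound 3 to compound 4 (0.08 log units; within the scatter), because the earlier step ran a 1.2-fold lower number from compound 1 to compound 2 (0.09 log units; within the scatter). Compound 4 is estimated at 20000 nM, with a likely range from 10000 nM to 40000 nM.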

Compound 4, half-maximal inhibitory concentration: 16900 nM
Compound 4: middle estimate off by 1.2-fold (0.07 log units), on the high side; the measured number falls inside the stated range.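

In this assay, moving from 2-fluorophenyl to 4-fluorophenyl on the amide-type nitrogen gave a 1.4-fold lower number from compound 3 to compound 4 (0.15 log units; within the scatter). Set beside the earlier step, the change looks the same on both cores: the same change on two cores in this assay, a 1.2-fold lower number (0.09 log units; within the scatter) from compound 1 to compound 2 and a 1.4-fold lower number (0.15 log units; within the scatter) from compound 3 to compound 4, 1.1-fold (0.05 log units) apart, within the scatter of two such steps. This shows that, on these two cores, the change carried over without a detectable difference; it does not show that the change itself moves the number on either core, since each step lies within the scatter, and two cores establish no rule for the whole series.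

The compounds shown leave open whether another group on that nitrogen, such as a chlorophenyl, a methoxyphenyl or a cyclohexyl, would move the number beyond the scatter. They also leave open whether a step of that kind would carry from one core to the other.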